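The source may report more compounds than this note shows. Statements on the series, on what has been measured and on what is new or still open speak of the compounds shown alone.

Measured compounds in a functional assay on A549 cells (Homo sapiens) for cytotoxicity, read by MTT assay, with a stated time of 72 h; a higher number here means a weaker inhibitor, a lower number a stronger inhibitor:
- compound 1 `COc1ccc(/C=N/NC(=O)Nc2ccc(Oc3ccnc(-c4nncn4CCN(C)C)c3)c(F)c2)c(OC)c1OC`: compound 1 gives 6680 nM
- compound 2 `CN(C)CCn1cnnc1-c1cc(Oc2ccc(NC(=O)N/N=C/c3ccc(F)cc3F)cc2F)ccn1`: compound 2 gives 1870 nM
- compound 3 `CN(C)CCn1cnnc1-c1cc(Oc2ccc(NC(=O)N/N=C/c3c(O)ccc4ccccc34)cc2F)ccn1`: compound 3 gives 880 nM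

Compound 3 holds the lowest number of the three; its nearest neighbour is compound 2, with a 2.1-fold lower number from compound 2 to compound 3 (0.33 log units; beyond the scatter), and the furthest is compound 1, with a 7.6-fold lower number from compound 1 to compound 3 (0.88 log units; beyond the scatter). The shared core is kept throughout and only the group on the carbon with a double bond to nitrogen varies.

Compound 4 `Cc1cc(/C=N/NC(=O)Nc2ccc(Oc3ccnc(-c4nncn4CCN(C)C)c3)c(F)c2)cc(C)c1O` is not yet measured. Its change from compound 3 is 4-hydroxy-3,5-dimethylphenyl in place of 2-hydroxynaphthalen-1-yl on a carbon with a double bond to nitrogen. Both known steps toward compound 3 lowered the number, so leaving 2-hydroxynaphthalen-1-yl is expected to raise it, modestly, as a 1.8-fold higher number from compound 3 to compound 4 (0.26 log units; within the scatter). For compound 4 the expected value in this assay is 1600 nM, within 600 nM to 4500 nM.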

Compound 4, half-maximal inhibitory concentration: 1640 nM
The estimate for compound 4 lay 1.0-fold (0.01 log units) below the measured number; measured number inside the range.
By their numbers in this assay, from the lowest: compounds 3, 4 and 2 (each within the scatter of the next, the first and the last beyond it); then compound 1.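

In this assay, the position on the carbon with a double bond to nitrogen accepts one six-membered aromatic ring in place of the two of 2-hydroxynaphthalen-1-yl, with a 1.9-fold higher number from compound 3 to compound 4 (0.27 log units; within the scatter) for 4-hydroxy-3,5-dimethylphenyl. That group and 2,4-difluorophenyl cannot be told apart, at a 1.1-fold lower number from compound 2 to compound 4 (0.06 log units; within the scatter), while 2,3,4-trimethoxyphenyl stays separate, at a 4.1-fold lower number from compound 1 to compound 4 (0.61 log units; beyond the scatter). No data shown explain these differences.

Open, as far as these compounds go, is how an amine or a carboxylic acid on the aromatic ring would read here, and whether 3,5-dimethylphenyl without the hydroxyl would match compound 4.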